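The source may hold more compounds than are shown below. What is called first, only, known or untested is meant among the compounds shown, and "the series" means these compounds.

Compound 1 `Clc1ccccc1-c1ccc2[nH]ncc2c1` gives 1230 nM.
Compound 2 `CC(C)c1cc2[nH]ncc2cc1-c1ccccc1C(F)(F)F` gives 25400 nM.

In an assay on CHO-TREX cells for antagonist activity at transient receptor potential cation channel subfamily A member 1 (Homo sapiens), read by FLIPR and calcium flux, with a stated time of 10 min (on this read-out higher numbers stand for weaker inhibition and lower numbers for stronger inhibition), compound 2 stands with the highest of the two numbers, and compound 1 sits a good deal lower, a gap beyond the scatter. Compound 3 `FC(F)(F)Oc1cc2[nH]ncc2cc1-c1ccccc1C(F)(F)F` differs from compound 2 by one change, (trifluoromethoxy in place of isopropyl on an aromatic carbon). For the measured compounds named here, no measured pair shows this exchange, so its effect is not known from the data. The account expects a modest step toward a lower number, a 1.7-fold lower number from compound 2 to compound 3 (0.23 log units; within the scatter), though a change within the scatter is also possible. For compound 3 the estimate in this assay is 15000 nM, within a range from 4000 nM to 50000 nM.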

Compound 3, half-maximal inhibitory concentration: 36 nM
Beside the measured number, compound 3's estimate is 420-fold (2.62 log units) above it, outside the stated range (below it).
By their numbers in this assay, from the lowest: compound 3; then compound 1; then compound 2.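

In this assay, trifluoromethoxy in place of isopropyl on this aromatic carbon, ortho to a large group, gives a 710-fold lower number from compound 2 to compound 3 (2.85 log units; beyond the scatter), so the group at this position has a large bearing on the read-out. The earlier compounds shown here could not show this, as compound 1 and compound 2 differ in more than one place. Nothing given here explains the size of the step. Going by these compounds, it remains open whether the oxygen or the fluorines carry the effect, and how a methoxy group, an amine or a carboxylic acid would behave at this position.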